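A few compounds are considered here, and "the series" means these few. Any claim that something is new, unique, unknown or untested is made for them only; others in the source may bear on it.

Measured so far in an assay on isolated protein for agonist activity at Toll-like receptor 8 (Homo sapiens); a lower number here means that less compound is needed, a higher number that more compound is needed for the effect: compound 1 `CCCCNc1nc(N)nnc1OCCCN(C)C` gives 100 nM; compound 2 `CCCCNc1nc(N)nnc1OCCOC` gives 1000 nM; compound 3 `CCCCNc1nc(N)nnc1OCc1ccccn1` gives 330 nM.

Compound 3 stands second highest of the three numbers. Its nearest neighbour is compound 2, and the step of a 3.0-fold lower number from compound 2 to compound 3 (0.48 log units; beyond the scatter); the step of a 3.3-fold higher number from compound 1 to compound 3 (0.52 log units; beyond the scatter) is of similar size the other way, so compound 3 sits between the two.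

Compound 4 `CCCCNc1nc(N)nnc1OCc1ccccc1` differs from compound 3 in one place: phenyl in place of pyridin-2-yl on a saturated chain carbon bound to an oxygen on an aromatic ring. Among the measured compounds shown here, no measured step swaps phenyl in; the steps of a 3.3-fold higher number from compound 1 to compound 3 (0.52 log units; beyond the scatter) and a 10-fold higher number from compound 1 to compound 2 (1.00 log units; beyond the scatter) both carry a loss of a basic nitrogen, each giving a higher number. Compound 4 removes the ring nitrogen of compound 3, so a modest step upward in this assay is expected: a 2.1-fold higher number from compound 3 to compound 4 (0.33 log units; beyond the scatter). Compound 4 is therefore estimated at 700 nM, within 300 nM to 2000 nM.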

Compound 4, half-maximal effective concentration: 1930 nM
Estimate against measurement, compound 4: 2.8-fold (0.44 log units) below, and the stated range covers the measured number.
By their numbers in this assay, from the lowest: compound 1; then compound 3; then compounds 2 and 4 (each within the scatter of the next).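

In this assay, phenyl in place of pyridin-2-yl, a change of one ring nitrogen to carbon, gives a 5.8-fold higher number from compound 3 to compound 4 (0.77 log units; beyond the scatter) and so moves the number at this position with the ring size unchanged. Phenyl and methoxymethyl are not separated, with a 1.9-fold higher number from compound 2 to compound 4 (0.29 log units; within the scatter), while phenyl in place of 2-(dimethylamino)ethyl gives a 19-fold higher number from compound 1 to compound 4 (1.29 log units; beyond the scatter), the largest step in the series. No measurement here explains the effect of the ring nitrogen. Open, on these data alone, is whether pyridin-4-yl would keep the number of compound 3, and whether a piperidine or a longer chain ending in dimethylamino would match compound 1.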